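The source may report more compounds than this note shows. Statements on the series, on what has been measured and on what is new or still open speak of the compounds shown alone.

Compound 1 `CC(C)(C)c1cc(NC(=O)Nc2cc(C(F)(F)F)cc(C(F)(F)F)c2)n(-c2ccccc2)n1` — 0 degrees C
Compound 2 `CC(C)(C)c1cc(NC(=O)Nc2cc(C(F)(F)F)cc(C(F)(F)F)c2)n(-c2ccc(Br)cc2)n1` — 0.1 degrees C
Compound 3 `Cn1nc(C(C)(C)C)cc1NC(=O)Nc1cc(F)cc(F)c1` — 1.2 degrees C

In an assay on isolated protein for inhibition of STE20-like serine/threonine-protein kinase (Homo sapiens), read by thermal shift assay, tested at 10 uM (on this read-out lower numbers stand for weaker stabilisation of the target and higher numbers for stronger stabilisation of the target against heat), compound 3 gives 1.2 degrees C, the highest of the three numbers: compound 2 lies a little lower, and compound 1 lower still, both gaps being beyond the scatter. Compound 4 `CC(C)(C)c1cc(NC(=O)Nc2cc(F)cc(F)c2)n(-c2ccc(Br)cc2)n1` differs from compound 3 in one place: 4-bromophenyl in place of methyl on an aromatic nitrogen. For the measured compounds named here, only one measured step bears on this change, and only at a distance: a number 0.10 degrees C higher from compound 1 to compound 2 (within the scatter), which shows that bromo in place of hydrogen on the ring in question leaves the read-out essentially where it was. Going by the values given here, no measured pair isolates the exchange of methyl for an aryl group on that nitrogen, since compound 1 and compound 2 also carry other groups on the urea-linked ring than compound 3 does. Compound 4 pairs the 4-bromophenyl of compound 2 with the difluorophenyl of compound 3, so its number could sit anywhere between them. On balance the step of a number 0.70 degrees C lower from compound 3 to compound 4 (within the scatter) is expected to be a modest drop, at the edge of the scatter. Compound 4 is therefore estimated at 0.5 degrees C, within a range of -0.6 degrees C to 1.6 degrees C.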

Compound 4, shift of the target's melting temperature: 0.5 degrees C
For compound 4 middle estimate and measured number coincide at the digits printed, within the range that was stated.
By their numbers in this assay, from the lowest: compounds 1, 2, 4 and 3 (each within the scatter of the next, the first and the last beyond it).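

For the compounds shown here, with the difluorophenyl urea held constant, the exchange on this aromatic nitrogen can be read directly for the first time: in this assay the step is a number 0.70 degrees C lower from compound 3 to compound 4 (within the scatter) and stays inside the usual scatter. A single methyl and a 4-bromophenyl, which brings a six-membered aromatic ring, therefore cannot be told apart at this position on this read-out, although the entering group is much the larger by heavy-atom count. The earlier step on the bromo group concerned only a hydrogen on an aryl ring already present, so it said nothing about replacing a small alkyl group with an aryl ring on the nitrogen itself. No measurement shown here offers an explanation for this result.

The compounds shown leave open whether a plain phenyl, a benzyl group, a longer chain such as n-butyl, or an aryl ring carrying an amine or a carboxylic acid on this nitrogen would move the read-out beyond the scatter. They also leave open whether the same exchange would read alike with the two trifluoromethyl groups of compound 2 on the urea-linked ring.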